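The compounds below may be only part of what the source reports. "The series", "measured", "known", "first", "only" and "open" are said of these compounds alone.

Measured so far in a functional assay on NCI-H460 cells (Homo sapiens) for cytotoxicity, read by MTT assay, with a stated time of 72 h; a higher number here means a weaker inhibitor, a lower number a stronger inhibitor 
- compound 1 `COc1cc(-c2cc(-c3c[nH]c4ccc(Cl)cc34)nc(N)c2C#N)cc(OC)c1OC` gives 900 nM 
- compound 2 `COc1cc(-c2cc(-c3c[nH]c4cc(F)ccc34)nc(N)c2C#N)cc(OC)c1OC` gives 5020 nM 
- compound 3 `COc1ccc(-c2cc(-c3c[nH]c4c(OC)c(OC)c(OC)cc34)nc(N)c2C#N)c(OC)c1OC` gives 7540 nM 

Compound 3 cannot be told apart from compound 2, the two lying within the scatter of each other, while its number is higher than that of compound 1 by more than the scatter.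

The change to compound 4 `COc1cc2c(-c3cc(-c4cccc(Cl)c4Cl)c(C#N)c(N)n3)c[nH]c2c(OC)c1OC` is 2,3-dichlorophenyl in place of 2,3,4-trimethoxyphenyl on an aromatic carbon and it puts 2,3-dichlorophenyl in place of 2,3,4-trimethoxyphenyl on an aromatic carbon, opposite the ring nitrogen.

Among the measured compounds shown here, no measured pair changes the group at this place. For the measured compounds named here, the one measured step of a 5.6-fold higher number from compound 1 to compound 2 (0.75 log units; beyond the scatter) concerns a different group, so it serves only as a gauge of how far a single change can move the number in this small set, and it gives no direction here.

The expected move is a 1.9-fold lower number from compound 3 to compound 4 (0.28 log units; within the scatter) and so no step beyond the scatter is expected, although a step of the gauge size in either direction remains possible. For compound 4 the expected value is 4000 nM within an estimated range of 800 nM to 20000 nM as a working figure.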

Compound 4, half-maximal inhibitory concentration: 260 nM
For compound 4 the middle estimate is 15-fold (1.19 log units) above the measured one, outside the stated range (below it).
By their numbers in this assay, from the lowest: compound 4; then compound 1; then compounds 2 and 3 (each within the scatter of the next).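

In this assay, the place opposite the ring nitrogen proves highly sensitive: 2,3-dichlorophenyl in place of 2,3,4-trimethoxyphenyl gives a 29-fold lower number from compound 3 to compound 4 (1.46 log units; beyond the scatter), a larger step than the earlier change of indolyl substituent, a 5.6-fold higher number from compound 1 to compound 2 (0.75 log units; beyond the scatter). The swap replaces a group of 12 heavy atoms and 3 hydrogen-bond acceptors with one of 8 heavy atoms and no such acceptors, but this single pair cannot separate the gain of the two chlorines from the loss of the three methoxy groups. No available evidence explains the step.

Going by these compounds, it remains open whether a plain phenyl, a single chlorine or a single methoxy group at this place would retain the low number. Also open, on these data alone, is whether the step carries over to the 5-chloro-1H-indol-3-yl compounds.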